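Series notes: bromo in place of methyl, compound 3 to compound 4

The compounds below may be only part of what the source reports. "The series", "measured", "known", "first", "only" and "open" are said of these compounds alone.

Measured so far:
compound 1, `COc1ccc(-c2nn(-c3ccccc3)cc2CNc2ccc(C)cc2)cc1`, in a functional assay on MCF7 cells (Homo sapiens) for antiproliferative activity, read by MTT assay, with a stated time of 48 h (a lower number here means a stronger inhibitor, a higher number a weaker inhibitor), gives 8160 nM
compound 2, `Cc1ccc(NCc2cn(-c3ccccc3)nc2-c2ccc(Cl)cc2)cc1`, in this assay gives 3110 nM
compound 3, `Cc1ccc(-c2nn(-c3ccccc3)cc2CNc2ccc(Br)cc2)cc1`, in this assay gives 6890 nM

Compound 3 stands second highest of the three numbers: its number and that of compound 1 lie within the scatter of each other, while compound 2 sits lower than compound 3 by a gap beyond the scatter. Compound 4 is `Brc1ccc(NCc2cn(-c3ccccc3)nc2-c2ccc(Br)cc2)cc1`. Its difference from compound 3: bromo in place of methyl on an aromatic carbon. Within the data shown here, the only measured step on that same ring is a 2.6-fold lower number from compound 1 to compound 2 (0.42 log units; beyond the scatter), where an entering chloro gave a modestly lower number; that step replaced methoxy rather than methyl, so it bears only loosely here. A small step toward a lower number, near the edge of the scatter, is therefore expected for compound 4 in this assay, namely a 1.6-fold lower number from compound 3 to compound 4 (0.21 log units; within the scatter). Compound 4 is estimated at 4200 nM, within the range 2000 nM to 9000 nM.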

Compound 4, half-maximal inhibitory concentration: 5000 nM
Compound 4: middle estimate off by 1.2-fold (0.08 log units), on the low side, and the stated range covers the measured number.
By their numbers in this assay, from the lowest: compounds 2, 4, 3 and 1 (each within the scatter of the next, the first and the last beyond it).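

Bromo in place of methyl on this ring gives a 1.4-fold lower number from compound 3 to compound 4 (0.14 log units; within the scatter) in this assay so the two groups cannot be told apart at this position. Chloro in place of methoxy on the same ring gave a 2.6-fold lower number from compound 1 to compound 2 (0.42 log units; beyond the scatter) and so, unlike this change, moved the number beyond the scatter. No evidence is available on the reason for either step.

On these data alone, whether an amine or a carboxylic acid at this position would move the number beyond the scatter stays open. So does whether any change at this position can take the series far from the low micromolar range of these compounds.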